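Swapping the Ether Ring in a Difluoroanilide Inhibitor

This account rests on a few compounds, and the source may have more. Where it says the series, first, only, none or still open, it means among the compounds named here.

Three amides built on one shared core were tested in an assay on isolated protein for inhibition of phosphodiesterase 4A (Sus scrofa); a higher number here means a weaker inhibitor, a lower number a stronger inhibitor. Compound 1 `COc1ccc(C(=O)Nc2ccccc2F)cc1OC1CCCC1` gives 10700 nM, compound 2 `COc1ccc(C(=O)Nc2c(F)cccc2F)cc1OC1CCCC1` gives 70 nM, and compound 3 `COc1ccc(C(=O)Nc2c(C)cccc2Cl)cc1OC1CCCC1` gives 100 nM. Compound 2 stands at the low end of these numbers: the step of a 150-fold lower number from compound 1 to compound 2 (2.18 log units; beyond the scatter) is large, whereas a 1.4-fold higher number from compound 2 to compound 3 (0.15 log units; within the scatter) lies within the scatter, and a 110-fold lower number from compound 1 to compound 3 (2.03 log units; beyond the scatter) is also large.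

Compound 4 `COc1ccc(C(=O)Nc2c(F)cccc2F)cc1OC1CCCCC1` differs from compound 2 by cyclohexyl in place of cyclopentyl on an oxygen on an aromatic ring. Every measured step changes the group on the amide nitrogen, so none bears directly on this change at the ether oxygen. For the measured compounds named here, with no guiding step, only a small move is expected, if anything toward a higher number, giving an expected step of a 2.1-fold higher number from compound 2 to compound 4 (0.33 log units; beyond the scatter). Compound 4 is estimated at 150 nM, within a range of 50 nM to 500 nM.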

Compound 4, half-maximal inhibitory concentration: 400 nM
The estimate for compound 4 lay 2.7-fold (0.43 log units) below the measured number, within the range that was stated.
By their numbers in this assay, from the lowest: compounds 2 and 3 (each within the scatter of the next); then compound 4; then compound 1.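

For the compounds shown here, for the first time, a change at the ether oxygen is read with the group on the amide nitrogen held fixed. Cyclohexyl in place of cyclopentyl gives a 5.7-fold higher number from compound 2 to compound 4 (0.76 log units; beyond the scatter), a modest step beyond the scatter, so this position responds to going from a five-membered to a six-membered ring. No evidence at hand accounts for this step. Still open, from the compounds shown here alone, is how a cyclobutyl ring or an isopropyl chain on this oxygen would read, and whether the same ring swap gives a similar step with 2-chloro-6-methylphenyl on the amide nitrogen.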